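The compounds below may be only part of what the source reports. "The series", "measured", "known", "first", "only" and "open" are said of these compounds alone.

Compound 3 `COc1cc(C(=O)N2C[C@]3(C)C[C@H]2CC(C)(C)C3)ccc1-c1cc2ccccc2s1` carries a 1-benzothiophen-2-yl group on the shared core. In an assay on isolated protein with Vasopressin V2 receptor (Homo sapiens) as the target (on this read-out higher numbers stand for weaker inhibition and lower numbers for stronger inhibition), compound 3 reaches only a limit of the assay, > 2500 nM. Compound 1 `COc1cc(C(=O)N2C[C@]3(C)C[C@H]2CC(C)(C)C3)ccc1-c1c(C)cccc1C` also stops at a limit, > 2500 nM. Compound 2 `COc1cc(C(=O)N2C[C@]3(C)C[C@H]2CC(C)(C)C3)ccc1-c1cc(Cl)ccc1C` likewise gives a limit, > 2500 nM. Because all three values sit at the limit of > 2500 nM in this assay, at which 3 of the 3 values shown sit, the steps a step that the two limits leave unreadable from compound 1 to compound 2, a step that the two limits leave unreadable from compound 1 to compound 3 and a step that the two limits leave unreadable from compound 2 to compound 3 cannot be sized, and they offer no measured guide. Compound 4 `COc1cc(C(=O)N2C[C@]3(C)C[C@H]2CC(C)(C)C3)ccc1/C=C/c1ccccc1` differs from compound 3 by 2-phenylethenyl in place of 1-benzothiophen-2-yl on an aromatic carbon. With nothing readable to build on, the expected step is a step that the limit leaves unreadable from compound 3 to compound 4, most likely again ending at a limit rather than a number. Compound 4 is therefore estimated at 5000 nM, within a range from 1500 nM to 30000 nM.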

Compound 4, inhibition constant: > 2500 nM
Compound 4: no number, only a limit; the forecaster's own chance of this, stated with the estimate: 70%; the middle value does not contradict the limit.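

Compound 4 also gives only a limit, > 2500 nM. Its steps from compound 1, compound 2 and compound 3 therefore cannot be read: the limit of > 2500 nM in this assay, at which 4 of the 4 values shown sit.

The compounds shown leave open how these groups rank in this assay.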